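The compounds below may be only part of what the source reports. "The series", "measured", "known", "first", "only" and "open" are said of these compounds alone.

Measured compounds:
- compound 1 `CCO/C(O)=C1\C(COCCNc2noc(N)n2)=NC(C)=C(C(=O)OC)C1c1cccc(Cl)c1Cl`: 3.16 nM
- compound 2 `CCO/C(O)=C1\C(COCC/N=C(/N)S)=NC(C)=C(C(=O)OC)C1c1cccc(Cl)c1Cl`: 1 nM
- compound 3 `CCO/C(O)=C1\C(COCCNc2cc(O)ncn2)=NC(C)=C(C(=O)OC)C1c1cccc(Cl)c1Cl`: 1.26 nM

In a functional assay (aorta) with Rattus norvegicus as the target (a lower number here means a stronger inhibitor, a higher number a weaker inhibitor), compound 1 gives 3.16 nM, the highest of the three numbers. Compound 2 gives 1 nM and compound 3 gives 1.26 nM; against compound 1 these read as a 3.2-fold lower number from compound 1 to compound 2 (0.50 log units; beyond the scatter) and a 2.5-fold lower number from compound 1 to compound 3 (0.40 log units; beyond the scatter), both beyond the scatter but modest. Between compound 2 and compound 3 the step is a 1.3-fold higher number from compound 2 to compound 3 (0.10 log units; within the scatter), within the scatter.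

Compound 4 `CCO/C(O)=C1\C(COCCNc2nccnc2NC)=NC(C)=C(C(=O)OC)C1c1cccc(Cl)c1Cl` has not yet been measured. It differs from compound 1 by 3-(methylamino)pyrazin-2-yl in place of 5-amino-1,2,4-oxadiazol-3-yl on an amine nitrogen. Both measured steps out of compound 1 bear on this, since each also replaces the 5-amino-1,2,4-oxadiazol-3-yl group on the amine nitrogen, and each gave a modestly lower number. Compound 3, which carries a six-membered aromatic ring there as compound 4 does, is the closer comparison. Compound 4 is therefore expected to give a modestly lower number than compound 1, a step of about a 2.0-fold lower number from compound 1 to compound 4 (0.30 log units; within the scatter), with the range wide enough that a value within the scatter of compound 1 remains possible. The estimate for compound 4 in this assay is 1.6 nM, between 0.6 nM and 4.5 nM.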

Compound 4, half-maximal inhibitory concentration: 5.01 nM
For compound 4 the middle estimate is 3.1-fold (0.50 log units) below the measured one; measured number outside the range, above it.
By their numbers in this assay, from the lowest: compounds 2 and 3 (each within the scatter of the next); then compounds 1 and 4 (each within the scatter of the next).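

In this assay a six-membered aromatic ring on the amine nitrogen does not by itself bring the lower number seen with compound 3: 3-(methylamino)pyrazin-2-yl in place of 5-amino-1,2,4-oxadiazol-3-yl gives a 1.6-fold higher number from compound 1 to compound 4 (0.20 log units; within the scatter) and so leaves compound 4 not distinguishable from compound 1. The two six-membered rings do part: 3-(methylamino)pyrazin-2-yl in place of 6-hydroxypyrimidin-4-yl gives a 4.0-fold higher number from compound 3 to compound 4 (0.60 log units; beyond the scatter) and shows that, among these compounds, the identity of the ring at this place counts and not its ring size alone. The group without a ring in compound 2 also stands apart, with a 5.0-fold higher number from compound 2 to compound 4 (0.70 log units; beyond the scatter) as the widest step to the new compound, and no measurement here accounts for any of these differences.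

On these data alone, whether the methylamino group itself is responsible for the separation from compound 3 stays open, and it would take 3-aminopyrazin-2-yl or plain pyrazin-2-yl on the same amine nitrogen to tell. Also open, as far as these compounds go, is whether a longer chain between the ether oxygen and the amine nitrogen would hold the number of compound 3 or shift it.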